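Notes on benzylsulfanyl sulfonyl amidines: chloro for trifluoromethyl

This account rests on a few compounds, and the source may have more. Where it says the series, first, only, none or still open, it means among the compounds named here.

Measured compounds in a functional assay on HCT-116 cells (Homo sapiens) for cytotoxicity, read by MTT assay, with a stated time of 72 h; a higher number here means a weaker inhibitor, a lower number a stronger inhibitor:
compound 1, `Cc1cc(S(=O)(=O)/N=C(\N)n2nccc2-c2ccccc2)c(SCc2ccc(C(F)(F)F)cc2)cc1Cl`, 14000 nM
compound 2, `Cc1cc(-c2ccccc2)n(/C(N)=N/S(=O)(=O)c2cc(C)c(Cl)cc2SCc2ccccc2)n1`, 10000 nM
compound 3, `Cc1cc(-c2ccccc2)n(/C(N)=N/S(=O)(=O)c2cc(C)c(Cl)cc2SCc2cccc(Cl)c2)n1`, 18000 nM

Compound 1 gives the second highest of the three numbers in this assay. Its nearest neighbour is compound 3, which gives 18000 nM, and its furthest is compound 2, which gives 10000 nM; both gaps lie within the scatter, so the three measured compounds cannot be placed in any order on these numbers.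

The unmeasured compound 4, `Cc1cc(S(=O)(=O)/N=C(\N)n2nccc2-c2ccccc2)c(SCc2ccc(Cl)cc2)cc1Cl`, differs from compound 1 in one place: chloro in place of trifluoromethyl on an aromatic carbon.

Going by the values given here, the only measured step on the benzylsulfanyl ring is a 1.8-fold higher number from compound 2 to compound 3 (0.26 log units; within the scatter). That step also puts a chloro onto the same ring, and it stays within the scatter. Among the compounds with values here, no measured pair shows the removal of a trifluoromethyl, so that part of the change has no direct precedent. With a single small step to go on, the expectation for compound 4 in this assay is a number close to that of compound 1, with no movement beyond the scatter in either direction.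

Compound 4 is therefore expected to give 14000 nM, with a range from 7000 nM to 28000 nM. The estimate corresponds to an expected no change at the digits printed from compound 1 to compound 4 (within the scatter).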

Compound 4, half-maximal inhibitory concentration: 7000 nM
For compound 4 the middle estimate is 2.0-fold (0.30 log units) above the measured one; low and high end bracket the measured number.
By their numbers in this assay, from the lowest: compounds 4, 2, 1 and 3 (each within the scatter of the next, the first and the last beyond it).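

Going by these compounds alone, replacing the 4-(trifluoromethyl)benzyl of compound 1 with the 4-chlorobenzyl of compound 4 gives, in this assay, a 2.0-fold lower number from compound 1 to compound 4 (0.30 log units; within the scatter), the first measured step in which a trifluoromethyl leaves the benzylsulfanyl ring. At this place, on an aromatic carbon para to a large group, a group of four heavy atoms can thus give way to a single chlorine with no movement beyond the scatter, and the two compounds cannot be told apart on these numbers. No measurement is at hand that could speak to what lies behind this result.

The compounds shown leave open how an amine, a carboxylic acid or a longer chain at this same place would read in this assay, since trifluoromethyl and chloro alone give no sense of how wide a range of groups the position accepts. They also leave open whether the exchange of trifluoromethyl for chloro would read the same way on the core of compound 2, which differs from that of compound 1 elsewhere in the molecule.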